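Swapping the aryl amine in a pyrimidine urea series

The source may hold more compounds than are shown below. What is called first, only, known or untested is meant among the compounds shown, and "the series" means these compounds.

Measured compounds:
compound 1, `COc1ccc(Br)cc1Nc1cc(NC(=O)Nc2c(Cl)cccc2Cl)ncn1`, 53.3%
compound 2, `COc1cc(NC(=O)Nc2cc(Nc3cc(Br)ccc3OC)ncn2)cc(OC)c1`, 23.1%
compound 3, `COc1ccc(C(F)(F)F)cc1Nc1cc(NC(=O)Nc2c(Cl)cccc2Cl)ncn1`, 69.1%

In a functional assay on NCI-H1581 cells (Homo sapiens) for inhibition, read by MTT assay, with a stated time of 48 h, tested at 10 uM (a lower number here means less inhibition, a higher number more inhibition at the concentration tested (going by the name of the read-out)), compound 2 gives 23.1%, the lowest of the three numbers; compound 1 lies above it by a number 30.2 percentage points lower from compound 1 to compound 2 (beyond the scatter) reversed, and compound 3 is further off still, at 69.1% for compound 3. The unmeasured compound 4, `COc1cc(NC(=O)Nc2cc(Nc3cc(C)cc(F)c3)ncn2)cc(OC)c1`, differs from compound 2 as follows: 3-fluoro-5-methylphenyl in place of 5-bromo-2-methoxyphenyl on a nitrogen on an aromatic ring.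

Two measured steps exist. The step of a number 30.2 percentage points lower from compound 1 to compound 2 (beyond the scatter) concerns the other aryl group on the urea and does not bear on this change. The step of a number 15.8 percentage points higher from compound 1 to compound 3 (beyond the scatter) does touch the aryl amine ring, but only swaps bromo for trifluoromethyl while keeping the methoxy, so it says little about removing the methoxy and moving to a fluoro and methyl pattern. Within the data shown here, no measured pair tests the change in hand directly, and the expectation for this assay is therefore a step of no clear direction, likely within or near the scatter, with compound 4 expected at 22% (5% to 42%), an expected step of a number 1.1 percentage points lower from compound 2 to compound 4 (within the scatter).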

Compound 4, a percentage reported as inhibition, at one concentration (the size of the read-out at that concentration, not a potency): 28.3%
The estimate for compound 4 lay 6.3 percentage points below the measured number; low and high end bracket the measured number.
By their numbers in this assay, from the lowest: compounds 2 and 4 (each within the scatter of the next); then compound 1; then compound 3.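

In this assay, the change on the nitrogen gives a number 5.2 percentage points higher from compound 2 to compound 4 (within the scatter), even though the methoxy and bromo groups both leave together and 3-fluoro-5-methylphenyl enters. Among these compounds, the only earlier change to this ring, a number 15.8 percentage points higher from compound 1 to compound 3 (beyond the scatter), kept the methoxy and carried 2,6-dichlorophenyl on the urea, whereas this step is read with 3,5-dimethoxyphenyl there, so it is the first reading of a wholesale ring swap and, in this setting, it stays within the scatter. Nothing is available that would explain this result.

From the compounds shown here alone, it remains open how 3-fluoro-5-methylphenyl reads with 2,6-dichlorophenyl on the urea, the group carried by compound 1 and compound 3. Also open, going by these compounds, is whether a morpholine or a carboxylic acid on this ring would shift the number beyond the scatter.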